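A few compounds are considered here, and "the series" means these few. Any claim that something is new, unique, unknown or untested is made for them only; others in the source may bear on it.

Measured so far:

- compound 1, `CCCCCCCCCCCCCCC(N)COCc1ccccc1`: 3000 nM in a functional assay on Jurkat cells (Homo sapiens) for inhibition; a lower number here means a stronger inhibitor, a higher number a weaker inhibitor
- compound 2, `CCCCCCCCCCCCCCC(COCc1ccccc1)NCC`: 6000 nM in this assay
- compound 3, `CCCCCCCCCCCCCCC(CN)NC(=O)OC(C)(C)C`: 6000 nM in this assay

Compound 4, `CCCCCCCCCCCCCCC(CNCC)NC(=O)OC(C)(C)C`, has not been measured in this assay.

The change from compound 1 to compound 2 is ethyl in place of hydrogen on an amine nitrogen. In this assay it made a 2.0-fold higher number from compound 1 to compound 2 (0.30 log units; within the scatter). The change from compound 3 to compound 4 is ethyl in place of hydrogen on an amine nitrogen. The place lines of the two changes read the same word for word, so this is the same change made on a different core. How the core of compound 3 differs from the core of compound 1 is not broken down here; the values of compound 1 and compound 3 in this assay sit within the scatter of each other, and compound 3 and compound 2 are level at the digits given.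

The only measured example of the change, from compound 1 to compound 2, gave a step inside the scatter, and nothing in the other pairs points to a different outcome on the core of compound 3. The step from compound 3 to compound 4 in this assay is therefore expected to be about a 2.0-fold higher number from compound 3 to compound 4 (0.30 log units; within the scatter), resting on a 2.0-fold higher number from compound 1 to compound 2 (0.30 log units; within the scatter). Compound 4 is estimated at 12000 nM in this assay, with the expected range from 5000 nM to 30000 nM, the width allowing for a second core and for measurement scatter.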

Compound 4, half-maximal inhibitory concentration: 6000 nM
The estimate for compound 4 lay 2.0-fold (0.30 log units) above the measured number; the range from low to high includes it.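

In this assay, among the compounds shown here, ethyl in place of hydrogen on an amine nitrogen gave no change at the digits printed from compound 3 to compound 4 (within the scatter), so on this second core, as on the first, the change produced no step that can be told from measurement noise. Set side by side, the two examples show no difference in how the change behaves on the two cores: the same change on two cores in this assay, a 2.0-fold higher number (0.30 log units; within the scatter) from compound 1 to compound 2 and no change at the digits printed (within the scatter) from compound 3 to compound 4, 2.0-fold (0.30 log units) apart, within the scatter of two such steps. For the compounds shown here, this supports carrying the change between these two cores with little expected consequence for the read-out, but it rests on only two pairs, does not establish that the change is truly neutral on either core, since a small real step could lie hidden in the scatter, and says nothing about any other core.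

Still open, from the compounds shown here alone, is whether a larger replacement on the same amine nitrogen, such as a butyl or benzyl group, or an acyl group such as acetyl, would give a step beyond the scatter on either core. Also open, going by these compounds, is how the ethyl change would read with a shorter or longer alkyl chain on the core, or with a carboxylic acid in place of the amine.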